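A few compounds are considered here, and "the series" means these few. Any claim that something is new, unique, unknown or untested is made for them only; others in the source may bear on it.

Measured so far:
compound 1 `Cc1nc2c([nH]1)C(=O)/C(=N/c1ccc(F)cc1)C(Cl)=C2O` — 3000 nM
compound 2 `Cc1nc2c([nH]1)C(=O)/C(=N/c1cccc(Br)c1)C(Cl)=C2O` — 1000 nM
compound 3 `Cc1nc2c([nH]1)C(=O)/C(=N/c1cccc(Cl)c1Cl)C(Cl)=C2O` — 600 nM

In a functional assay (Rattus norvegicus) for antiproliferative activity (a higher number here means a weaker inhibitor, a lower number a stronger inhibitor), compound 3 gives the lowest of the three numbers, though compound 2 stands within the scatter of it; only compound 1 is clearly higher. Compound 4 `Cc1nc2c([nH]1)C(=O)/C(=N/c1cccc(Cl)c1)C(Cl)=C2O` differs from compound 3 in one place: hydrogen in place of chloro on an aromatic carbon. For the measured compounds named here, no measured step removes a chloro group from this ring. Going by the values given here, the single one-place step on record, a 3.0-fold lower number from compound 1 to compound 2 (0.48 log units; beyond the scatter), concerns a different change and is modest. The closest measured analogue of compound 4 is compound 2, which carries 3-bromophenyl on the same double-bonded nitrogen, and its number is within the scatter of compound 3. Compound 4 is therefore expected to change by a 1.5-fold higher number from compound 3 to compound 4 (0.18 log units; within the scatter), that is, not beyond the scatter. Compound 4 is estimated at 900 nM, in the range 450 nM to 2000 nM.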

Compound 4, half-maximal inhibitory concentration: 900 nM
Beside the measured number, compound 4's estimate shows no gap at the digits printed, within the range that was stated.
By their numbers in this assay, from the lowest: compounds 3, 4 and 2 (each within the scatter of the next); then compound 1.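

In this assay, hydrogen in place of chloro on this aromatic carbon gives a 1.5-fold higher number from compound 3 to compound 4 (0.18 log units; within the scatter) and so shows no measurable dependence on this chloro group. Chloro in place of bromo gives a 1.1-fold lower number from compound 2 to compound 4 (0.05 log units; within the scatter) and does not separate these two halogens in this series. Only 3-chlorophenyl in place of 4-fluorophenyl gives a step beyond the scatter, a 3.3-fold lower number from compound 1 to compound 4 (0.52 log units; beyond the scatter) and still a modest one.

Open, as far as these compounds go, is whether an amine or a carboxylic acid on this aromatic carbon would shift the number beyond the scatter. No measurement at hand explains any of these steps.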